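Ester or Acid at the Carbonyl of Compound 2

This account rests on a few compounds, and the source may have more. Where it says the series, first, only, none or still open, it means among the compounds named here.

Compound 2 `COCCOC(=O)c1ccc(-c2ccc(NC(=O)c3ccc(OC)c(CCCN(C)C)c3)cc2)c(C)c1` gives 3.16 nM in an assay on striatum for binding affinity to 5-hydroxytryptamine receptor 1D (Cavia porcellus), in the presence of a further agent that is not named here; on this read-out lower numbers stand for stronger inhibition and higher numbers for weaker inhibition. Compound 1 `COc1ccc(C(=O)Nc2ccc(-c3ccc(C=O)cc3C)cc2)cc1CCCN(C)C` gives 6.31 nM in this assay, and the step of a 2.0-fold lower number from compound 1 to compound 2 (0.30 log units; within the scatter) means the two numbers sit within the scatter of each other. Compound 3 `COc1ccc(C(=O)Nc2ccc(-c3ccc(C(=O)O)cc3C)cc2)cc1CCCN(C)C` differs from compound 2 by hydrogen in place of 2-methoxyethyl on an oxygen next to a carbonyl group, so (2-methoxyethoxy)carbonyl becomes carboxy. Within the data shown here, no measured step covers this exchange; the one step known changed the same carbonyl carbon without moving beyond the scatter. A modest shift toward a higher number, or none beyond the scatter, is therefore expected. For compound 3 the estimate is 8 nM, between 2 nM and 40 nM, a step of a 2.5-fold higher number from compound 2 to compound 3 (0.40 log units; beyond the scatter).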

Compound 3, inhibition constant: 31.6 nM
Estimate against measurement, compound 3: 4.0-fold (0.60 log units) below; the measured number falls inside the stated range.
By their numbers in this assay, from the lowest: compounds 2 and 1 (each within the scatter of the next); then compound 3.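

In this assay, among these compounds, this carbonyl position proves sensitive: removing 2-methoxyethyl from the oxygen gives a 10-fold higher number from compound 2 to compound 3 (1.00 log units; beyond the scatter) and is the first change here to pass beyond the scatter. Placing hydroxy on the carbonyl carbon in place of hydrogen gives a 5.0-fold higher number from compound 1 to compound 3 (0.70 log units; beyond the scatter) as well, so carboxy stands apart from two groups that could not be told apart. Nothing available here offers a reason for this result.

Still open, on these data alone, is whether a methyl ester or a primary amide at this carbonyl would sit with compound 2 or with compound 3.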